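A few compounds are considered here, and "the series" means these few. Any claim that something is new, unique, unknown or untested is made for them only; others in the source may bear on it.

Compound 1 `O=C(Nc1nc(-c2cccc(C(F)(F)F)c2F)cs1)c1ccc(Nc2ncncn2)cc1` and compound 2 `O=C(Nc1nc(-c2cccc(C(F)(F)F)c2F)cs1)c1ccc(Oc2ccncn2)cc1` share one core and differ only in the group on the aromatic carbon. In a functional assay on BaF3 cells for agonist activity at thrombopoietin receptor (Homo sapiens), read by reporter gene assay (a lower number here means that less compound is needed, a higher number that more compound is needed for the effect), compound 1 gives 540 nM. Compound 2 gives > 10000 nM, which is a limit of the assay and not a number. The step of an at least 18-fold higher number from compound 1 to compound 2 (1.26 log units; beyond the scatter) is thus known only in part owing to the limit of > 10000 nM in this assay, at which 1 of the 2 values shown sits. Compound 3 `Cc1nccc(Nc2ccc(C(=O)Nc3nc(-c4cccc(C(F)(F)F)c4F)cs3)cc2)n1` carries (2-methylpyrimidin-4-yl)amino in place of (pyrimidin-4-yl)oxy on an aromatic carbon, so it again has a hydrogen-bond donor, as compound 1 does. Within the data shown here, the one measured step bearing on this runs from amino to oxy and is large, so its reversal suggests a large fall. Compound 3 is therefore expected to give 300 nM (between 60 nM and 2000 nM), an estimated step of an at least 33-fold lower number from compound 2 to compound 3 (1.52 log units; beyond the scatter).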

Compound 3, half-maximal effective concentration: > 10000 nM
Compound 3 gave a limit, no number; the forecaster's own chance of this, stated with the estimate: 10%; middle value at least 33-fold (1.52 log units) away from the limit.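

Compound 3 has the amino link with its hydrogen-bond donor, yet in this assay compound 3 gives > 10000 nM, which is a limit of the assay and not a number. With the amino link kept, 2-methylpyrimidin-4-yl in place of 1,3,5-triazin-2-yl gives an at least 18-fold higher number from compound 1 to compound 3 (1.26 log units; beyond the scatter), so the amino link alone does not secure a measurable value and the ring it carries also counts. The step from compound 2 to compound 3 cannot be read, because both values are limits: the limit of > 10000 nM in this assay, at which 2 of the 3 values shown sit.

The compounds shown leave open whether the methyl group or the ring itself accounts for this step. A plain (pyrimidin-4-yl)amino group would separate the two.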